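Methoxy added to a tetracyclic indoline ester

A few compounds are considered here, and "the series" means these few. Any claim that something is new, unique, unknown or untested is made for them only; others in the source may bear on it.

In a functional assay on T47D cells (Homo sapiens) for inhibition, read by sulforhodamine B assay, with a stated time of 48 h (on this read-out higher numbers stand for weaker inhibition of growth and lower numbers for stronger inhibition of growth), compound 1 `COC(=O)[C@@]1(C)CCC=C2[C@@H]1CC[C@@H](C)[C@]2(C)Cc1c[nH]c2ccc(C)cc12` gives 20000 nM and compound 2 `COC(=O)[C@@]1(C)CCC=C2[C@@H]1CC[C@@H](C)[C@]2(C)Cc1c[nH]c2c(C)cccc12` gives 18000 nM. Compound 3 `COC(=O)[C@@]1(C)CC[C@@H]2C3=C1CC[C@@H](C)[C@]3(C)C[C@@H]1c3ccccc3N[C@H]21` gives 35000 nM in this assay, and the gaps from compound 3 to compound 1 and to compound 2 both lie within the usual scatter of such measurements, so the three numbers cannot be told apart. Compound 4 `COC(=O)[C@@]1(C)CC[C@@H]2C3=C1CC[C@@H](C)[C@]3(C)C[C@@H]1c3cc(OC)ccc3N[C@H]21` is compound 3 with one change: methoxy in place of hydrogen on an aromatic carbon. For the measured compounds named here, no measured pair in this set shows the effect of such a change, and no other measured compound carries this group, so nothing in the data points to either direction. Compound 4 is therefore expected to give a number near that of compound 3 in this assay, with the step of a 1.2-fold lower number from compound 3 to compound 4 (0.07 log units; within the scatter) not exceeding the scatter. The estimate for compound 4 is 30000 nM, with a range from 10000 nM to 90000 nM, because compound 3 itself gives 35000 nM and the change is small.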

Compound 4, concentration for 50% growth inhibition: 19000 nM
Compound 4: middle estimate off by 1.6-fold (0.20 log units), on the high side; the range from low to high includes it.
By their numbers in this assay, from the lowest: compounds 2, 4, 1 and 3 (each within the scatter of the next).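

In this assay, for the compounds shown here, the pair gives the first direct reading of a change on the shared core: methoxy in place of hydrogen on an aromatic carbon, meta to a fused ring and para to a fused ring, gives a 1.8-fold lower number from compound 3 to compound 4 (0.27 log units; within the scatter), so the two compounds cannot be told apart. At this one position, then, adding this group leaves the read-out inside the scatter, and the pair shows no measurable effect in either direction. Nothing available bears on why this is so.

The compounds shown leave open whether an amine, a carboxylic acid or a longer chain such as ethoxy on this same carbon would give a step beyond the scatter. They also leave open whether methoxy on another carbon of this aromatic ring would read the same.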